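Swapping a methyl for a hydroxyl on the pendant phenyl ring

The compounds below may be only part of what the source reports. "The series", "measured", "known", "first", "only" and "open" are said of these compounds alone.

Compound 2, `C=C(C)[C@@H]1CC=C(C)/C(=N/NC(=O)Nc2nnc(-c3ccc(C)cc3)o2)C1`, was tested in a functional assay on the whole organism (strain Swiss albino) with Mus musculus as the target, with a stated time of 4 h (on this read-out higher numbers stand for an effect only at larger amounts of compound and lower numbers for an effect already at smaller amounts), where compound 2 gives 300 mg/kg. Its closest relative, compound 1, `C=C(C)[C@@H]1CC=C(C)/C(=N/NC(=O)Nc2nnc(-c3ccccc3)o2)C1`, differs only by carrying hydrogen where compound 2 carries a methyl on an aromatic carbon; in this assay compound 1 gives 300 mg/kg, so the step of no change at the digits printed from compound 1 to compound 2 (within the scatter). Compound 2 therefore stands level with compound 1, and nothing in these two values separates them.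

Compound 3, `C=C(C)[C@@H]1CC=C(C)/C(=N/NC(=O)Nc2nnc(-c3ccccc3O)o2)C1`, has not yet been measured. Relative to compound 2 the change is 2-hydroxyphenyl in place of 4-methylphenyl on an aromatic carbon. Among the measured compounds shown here, the only measured step, that from compound 1 to compound 2, also altered the same phenyl ring and left the minimum effective dose unchanged; no measured step involves a hydroxyl group, so the effect of the entering group is unknown from these data. On that basis the step is expected to be small: no change at the digits printed from compound 2 to compound 3 (within the scatter). Compound 3 is estimated to give 300 mg/kg, with a likely range from 100 mg/kg to 600 mg/kg.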

Compound 3, minimum effective dose: 300 mg/kg
For compound 3 middle estimate and measured number coincide at the digits printed; low and high end bracket the measured number.
By their numbers in this assay, from the lowest: compounds 1, 2 and 3 (each within the scatter of the next).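

In this assay, swapping 4-methylphenyl for 2-hydroxyphenyl gives no change at the digits printed from compound 2 to compound 3 (within the scatter), and hydroxy in place of hydrogen on the same phenyl ring gives no change at the digits printed from compound 1 to compound 3 (within the scatter) as well. The earlier pair showed only that a methyl, a carbon group, leaves the minimum effective dose where it was; this result extends that to an oxygen-bearing group with 1 hydrogen-bond donor and 1 hydrogen-bond acceptor, neither of which 4-methylphenyl has, and to a 2-substituted ring alongside a 4-substituted one. No supporting measurement is available to explain why the read-out stays the same across these changes.

From the compounds shown here alone, with all three compounds level, it remains open whether this pendant ring can influence the dose at all, or whether these particular groups simply happen to match. An amine or a carboxylic acid on the phenyl ring, a longer chain such as butyl in place of the methyl, or 4-hydroxyphenyl as the direct partner of 4-methylphenyl could each help settle that question.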